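Compound 1 to compound 3: rejoined group on oxygen

The source may report more compounds than this note shows. Statements on the series, on what has been measured and on what is new or still open speak of the compounds shown alone.

In a functional assay on A549 cells (Homo sapiens) for cytotoxicity, read by MTT assay, with a stated time of 48 h (a higher number here means a weaker inhibitor, a lower number a stronger inhibitor), two compounds have been measured so far. Compound 1 (`COc1cccc(/C=C/C(=O)c2cccc(-n3cc(COc4ccc5ccc(=O)oc5c4)nn3)c2)c1OC`) gives 31400 nM, the higher of the two numbers. Compound 2 (`COc1cccc(/C=C/C(=O)c2ccc(-n3cc(COc4ccc5ccc(=O)oc5c4)nn3)cc2)c1OC`) gives 7950 nM, and the gap between the two lies beyond the usual scatter, with compound 1 the weaker inhibitor.

The next compound to be read is compound 3 (`COc1cccc(/C=C/C(=O)c2cccc(-n3cc(COc4cc(=O)oc5ccccc45)nn3)c2)c1OC`). Its change from compound 1 is a group of 11 heavy atoms (9 carbon, 2 oxygen; one six-membered aromatic ring of carbon only, one six-membered aromatic ring with 1 hetero atom) in place of a group of 11 heavy atoms (9 carbon, 2 oxygen; one six-membered aromatic ring of carbon only, one six-membered aromatic ring with 1 hetero atom), on an oxygen on a saturated carbon. The two compounds have the same atoms, joined differently, and the exchanged group sits on an oxygen on a saturated carbon. Both groups have the same counted make-up, so the count alone gives no direction.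

Within the data shown here, no measured pair shows this change, so the expectation is weakly founded. No step beyond the scatter is expected in this assay, with at most a slight shift towards a lower number. The expected change is a 1.4-fold lower number from compound 1 to compound 3 (0.15 log units; within the scatter). The wide range is an allowance for that missing evidence. For compound 3 the estimated value is 22000 nM, with an expected range of 8000 nM to 60000 nM.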

Compound 3, half-maximal inhibitory concentration: 18100 nM
Beside the measured number, compound 3's estimate is 1.2-fold (0.08 log units) above it; measured number inside the range.
By their numbers in this assay, from the lowest: compound 2; then compounds 3 and 1 (each within the scatter of the next).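

Working note on the group on an oxygen on a saturated carbon: in this assay, swapping one group for its rejoined form, with the same atoms and the same counted make-up, gives a 1.7-fold lower number from compound 1 to compound 3 (0.24 log units; within the scatter) and so does not separate the two compounds. Among these compounds, this is the first reading of any change at this position, and it shows that, for this one pair on the core of compound 1, the way the group is joined carries no effect that can be told from assay noise. No supporting measurement bears on this result, so the step stands as a bare comparison of two numbers.

Still open, on these data alone, is whether the same rejoining on the core of compound 2 would also stay within the scatter, since a single pair on one core says nothing about the other. Also open, as far as these compounds go, is whether a quite different group on that oxygen, such as a plain phenyl group or a longer chain ending in an amine, would move the number beyond the scatter.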